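The source may hold more compounds than are shown below. What is called first, only, known or untested is meant among the compounds shown, and "the series" means these compounds.

Of the compounds shown here, two have been tested in a functional assay on L1210 cells (Mus musculus), with a stated time of 12 days; on this read-out higher numbers stand for higher potency (the scale is a negative logarithm) and lower numbers for lower potency. Compound 1, `CC1=C(N2CC2)C(=O)C(CC(C)OC(N)=O)=C(N2CC2)C1=O`, gives 5.79 in this assay, and compound 2, `COCCC1=C(N2CC2)C(=O)C(CCOC)=C(N2CC2)C1=O`, gives 5.31. Going by the values given here, compound 1 thus stands highest of the two numbers known, with compound 2 the nearer at a gap beyond the usual scatter. The step now followed leads from compound 1 to compound 3, `CC1=C(N2CC2)C(=O)C(C2CCCCC2)=C(N2CC2)C1=O`, and the change is a group of 6 heavy atoms (6 carbon; one six-membered non-aromatic ring of carbon only) in place of a group of 7 heavy atoms (4 carbon, 1 nitrogen, 2 oxygen; no ring), on a double-bonded ring carbon. A cyclohexyl, with no hydrogen-bond donors or acceptors, takes the place of the open-chain group that carried one hydrogen-bond donor and two hydrogen-bond acceptors. Among the compounds with values here, no comparable step has been measured, so the direction must be judged from the two values alone; the expectation is a loss of potency in this assay of moderate size, beyond the scatter, for the step of a number 0.59 log units lower from compound 1 to compound 3 (beyond the scatter). Compound 3 is therefore estimated at 5.2, with a range from 4.6 to 5.8.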

Compound 3, logarithm of the reciprocal of the active concentration, log(1/C): 5.39
Compound 3: middle estimate off by 0.19 log units, on the low side; the measured number falls inside the stated range.
By their numbers in this assay, from the lowest: compounds 2 and 3 (each within the scatter of the next); then compound 1.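

In this assay, putting cyclohexyl in place of the open-chain group on the double-bonded ring carbon gives a number 0.40 log units lower from compound 1 to compound 3 (beyond the scatter), a modest step. With the methyl group, both aziridin-1-yl groups and the rest of the core held as in compound 1, this position therefore bears on the read-out, yet with a carbon-only ring and no hydrogen-bond donors or acceptors there, compound 3 still gives 5.39. Nothing measured here gives a cause for this step.

Because this one step changes the ring, the donor and the acceptors together, it leaves open which of them goes with the lower number. From the compounds shown here alone, it also remains open whether a phenyl group, an amine or a plain hexyl chain on this carbon would stand nearer compound 1 or compound 3.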